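Chalcone amides: chloro to methoxy on the aryl ring

The source may hold more compounds than are shown below. What is called first, only, known or untested is meant among the compounds shown, and "the series" means these compounds.

The series is scored in a functional assay on the whole organism (strain albino) for inhibition, with Rattus norvegicus as the target, read by paw edema, with stated times of 30 min and 3 h, at a dose of 100 mg/kg by the oral route; a higher number here means more inhibition at the dose given (going by the name of the read-out), a lower number less inhibition. Within the data shown here, compound 1 `COc1ccc(/C=C/C(=O)c2ccc(NC(=O)CBr)cc2)cc1` gives 46% in this assay, and compound 2 `COc1ccc(/C=C/C(=O)c2ccc(NC(=O)C(C)Br)cc2)cc1` gives 40%, the one measured step being a number 6 percentage points lower from compound 1 to compound 2 (within the scatter). Compound 3 `CC(O[N+](=O)[O-])C(=O)Nc1ccc(C(=O)/C=C/c2ccc(Cl)cc2)cc1` gives 62%, the highest of the three numbers; compound 1 stands below it by an amount beyond the scatter, and compound 2 stands lower still, also beyond the scatter. Among the measured compounds shown here, no single-change step links compound 3 to either of those two, so their gap is read only from the values.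

Compound 4 `COc1ccc(/C=C/C(=O)c2ccc(NC(=O)C(C)O[N+](=O)[O-])cc2)cc1` differs from compound 3 in one place: methoxy in place of chloro on an aromatic carbon. For the measured compounds named here, no measured step in this assay touches that aryl substituent; the only measured step concerns the chain bearing the bromine, and it lies within the scatter. The expectation for compound 4 therefore rests on the value of compound 3 with a wide margin, and the step of a number 7 percentage points lower from compound 3 to compound 4 (within the scatter) is expected to be small, possibly within the scatter, with the direction uncertain. For compound 4 the estimated value in this assay is 55%, expected to fall between 40% and 68%.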

Compound 4, a percentage reported as inhibition, in the whole organism at one dose (the size of the read-out at that dose, not a potency): 50%
The estimate for compound 4 lay 5 percentage points above the measured number; measured number inside the range.
By their numbers in this assay, from the lowest: compounds 2, 1 and 4 (each within the scatter of the next); then compound 3.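

In this assay, the change from 4-chlorophenyl to 4-methoxyphenyl gives the first measured step at this aromatic carbon, a number 12 percentage points lower from compound 3 to compound 4 (beyond the scatter) with the chain held as the nitrooxy amide, and this modest step is the only single-place change shown that lies beyond the scatter. With the methoxy group held, the chain changes stay within the scatter: nitrooxy in place of bromo gives a number 10 percentage points higher from compound 2 to compound 4 (within the scatter) and 1-(nitrooxy)ethyl in place of bromomethyl gives a number 4 percentage points higher from compound 1 to compound 4 (within the scatter) in this read-out, so among these methoxy compounds the nitrooxy chain does not separate from the bromo chains. No measured evidence accounts for the gap between the chloro compound and its methoxy partner.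

Still open, going by these compounds, is whether the gap between chloro and methoxy carries over to the bromo chains of compound 1 and compound 2. Also open, on these data alone, is how an amine or a carboxylic acid on this aromatic carbon, or a longer chain on the carbon bearing the nitrooxy group, would read in this assay.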